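Benzyl for tolyl on sulfur: two pairs, one measured

The source may hold more compounds than are shown below. What is called first, only, known or untested is meant among the compounds shown, and "the series" means these compounds.

Compound 2 `Cc1ccc(S/C(=C/c2sccc2C)C(=O)c2ccc(Cl)cc2)cc1` and compound 1 `Cc1ccsc1/C=C(/SCc1ccc(Cl)cc1)C(=O)c1ccc(Cl)cc1` share a core and differ only at the sulfur. In a functional assay on DU-145 cells (Homo sapiens) for inhibition, read by trypan blue exclusion, with a stated time of 96 h (a higher number here means a weaker inhibitor of growth, a lower number a stronger inhibitor of growth), compound 2 gives 50000 nM, and compound 1 gives 50000 nM. The change 4-chlorobenzyl in place of 4-methylphenyl on a sulfur therefore gives no change at the digits printed from compound 2 to compound 1 (within the scatter); both numbers sit at the top of the range seen here, so the step says little about what the swap does to a compound that inhibits growth more strongly.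

Compound 3 `Cc1ccc(S(=O)(=O)/C(=C/c2ccccc2OCc2ccccc2)C(=O)c2ccc(Br)cc2)cc1` carries a different core; the difference between the core of compound 3 and the core of compound 2 is not broken down here. In this assay compound 3 gives 1000 nM, the lowest of the three numbers and beyond the scatter from both compound 1 and compound 2.

Compound 4 `O=C(/C(=C\c1ccccc1OCc1ccccc1)S(=O)(=O)Cc1ccc(Cl)cc1)c1ccc(Br)cc1` is not yet measured. It relates to compound 3 through (4-chlorobenzyl in place of 4-methylphenyl on a sulfonyl sulfur). This is the same kind of change as from compound 2 to compound 1, though not the same: in the earlier pair the place is a sulfur whose other neighbours are a double-bonded chain carbon, whereas here it is a sulfonyl sulfur whose other neighbours are a double-bonded chain carbon.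

Going by the values given here, the only precedent, no change at the digits printed from compound 2 to compound 1 (within the scatter), shows no movement, so the expectation for compound 4 is a step of a 1.2-fold higher number from compound 3 to compound 4 (0.08 log units; within the scatter), resting on that pair and on the value of compound 3 1000 nM. Compound 4 is estimated at 1200 nM, with a range from 300 nM to 6000 nM because the earlier pair was read near the ceiling and may hide a real shift.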

Compound 4, concentration for 50% growth inhibition: 10000 nM
For compound 4 the middle estimate is 8.3-fold (0.92 log units) below the measured one; measured number outside the range, above it.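

In this assay, the 4-chlorobenzyl for 4-methylphenyl swap on the sulfonyl sulfur gives a 10-fold higher number from compound 3 to compound 4 (1.00 log units; beyond the scatter), whereas the same kind of swap on the sulfur of the other core gave no change at the digits printed from compound 2 to compound 1 (within the scatter). Going by these compounds alone, the change therefore does not carry from one core to the other at a single size, and the flat step on the first core is a poor guide to the second: the same change on two cores in this assay, no change at the digits printed (within the scatter) from compound 2 to compound 1 and a 10-fold higher number (1.00 log units; beyond the scatter) from compound 3 to compound 4, 10-fold (1.00 log units) apart, beyond the scatter of two such steps This comparison rests on only two pairs, and it does not show which difference between the cores, the sulfonyl sulfur or the rest of the structure, goes with the gap; compound 1 and compound 2 also both sit at the top of the range seen here, so their flat step may understate what the swap can do.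

The compounds shown leave open whether the step from compound 3 to compound 4 follows the chlorine, the extra carbon of the benzyl group or both, which a plain benzyl or a 4-chlorophenyl on the sulfonyl sulfur would separate. Also open, on these data alone, is how the sulfonyl core responds to quite different groups at that place, such as a longer chain ending in an amine or a carboxylic acid.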